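The source may hold more compounds than are shown below. What is called first, only, known or untested is meant among the compounds shown, and "the series" means these compounds.

Measured so far:
- compound 1, `[N-]=[N+]=Nc1nccc2c1ncn2[C@H]1C[C@H](O)[C@@H](CO)O1`: 4% in a functional assay (Homo sapiens) for inhibition of Nucleic Acid, tested at 100 uM; a lower number here means less inhibition, a higher number more inhibition at the concentration tested (going by the name of the read-out)
- compound 2, `CN(C)c1[nH]ccc2ncnc1-2`: 8% in this assay

Both measured compounds give only small readings. In this assay compound 2 gives 8% and compound 1 gives 4%; the two numbers lie within the usual scatter of each other, so nothing separates the two compounds on these data, and the inhibition in this assay is level between them. Compound 2 is the starting point for the next step.

Compound 3, `Nc1[nH]ccc2ncnc1-2`, has not yet been measured. It differs from compound 2 in one place: amino in place of dimethylamino on an aromatic carbon. The shared core is kept.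

Among the measured compounds shown here, with only two measured compounds, and no measured pair that differs in a single place, there is no step to lean on. What can be said is that both compounds tested in this assay sit near the bottom of the scale, and the exchange of one small group for another is not expected to move the reading far. The step from compound 2 to compound 3 is therefore expected to be a number 1 percentage points lower from compound 2 to compound 3 (within the scatter), which is within the scatter. Compound 3 is estimated to give 7%, with a likely range from -5% to 20%.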

Compound 3, a percentage reported as inhibition, at one concentration (the size of the read-out at that concentration, not a potency): 60%
Compound 3: the middle estimate sits 53 percentage points below what was measured; the whole stated range lies below it.
By their numbers in this assay, from the lowest: compounds 1 and 2 (each within the scatter of the next); then compound 3.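

In this assay, amino in place of dimethylamino on this aromatic carbon, next to the ring nitrogen, gives a number 52 percentage points higher from compound 2 to compound 3 (beyond the scatter), so the reading at this position depends strongly on the group attached there. The step also shows that a change confined to one small group can lift the reading well clear of the bottom of the scale, which the first two compounds gave no sign of. Two things change together in this step, since the group goes from 3 heavy atoms to 1 and from 0 hydrogen-bond donors to 1, and no available evidence explains the rise or separates these two changes.

The compounds shown leave open how methylamino, which keeps just one of the two methyl groups on the nitrogen, would read at this position, and such a group could help separate the effect of size from that of the hydrogen-bond donor. They also leave open whether the nitrogen itself matters, which a hydroxyl or a small alkyl group such as ethyl on the same carbon could help to show.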